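This account rests on a few compounds, and the source may have more. Where it says the series, first, only, none or still open, it means among the compounds named here.

Measured in a functional assay on MDA-MB-231 cells (Homo sapiens) for antiproliferative activity, read by MTT assay, with a stated time of 72 h; a higher number here means a weaker inhibitor, a lower number a stronger inhibitor:
Compound 1 `CCNC(=O)CCc1cccc2c1B(O)OC2`: > 100000 nM, a limit
Compound 2 `O=C(CCc1cccc2c1B(O)OC2)Nc1nccs1`: > 100000 nM, a limit
Compound 3 `O=C(CCc1cccc2c1B(O)OC2)Nc1ccc(Br)cc1`: 5300 nM

Compound 3 is the only one of the three to give a number, and it is the strongest of them. Compounds 1 and 2 stop at the limit of > 100000 nM in this assay, at which 2 of the 3 values shown sit.

Compound 4 `COc1ccc(NC(=O)CCc2cccc3c2B(O)OC3)cc1` differs from compound 3 in a single group: methoxy in place of bromo on an aromatic carbon. Methoxy stands in place of bromo on an aromatic carbon, para to a large group.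

Within the data shown here, two measured steps bear on this only indirectly: an at least 18-fold lower number from compound 1 to compound 3 (1.27 log units; beyond the scatter) and an at least 18-fold lower number from compound 2 to compound 3 (1.27 log units; beyond the scatter). Both are large, and both bring in the whole 4-bromophenyl on the amide-type nitrogen. Among the measured compounds shown here, no measured step changes the bromo alone.

Compound 4 keeps the phenyl of compound 3 at 5300 nM, so a step of that size is not expected. A moderate move toward a higher number in this assay is expected instead. The expected step is a 2.3-fold higher number from compound 3 to compound 4 (0.35 log units; beyond the scatter). For compound 4 the estimated value is 12000 nM, with an expected range of 3000 nM to 60000 nM.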

Compound 4, half-maximal inhibitory concentration: 850 nM
Compound 4: the middle estimate sits 14-fold (1.15 log units) above what was measured, outside the stated range (below it).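

Replacing bromo with methoxy gives a 6.2-fold lower number from compound 3 to compound 4 (0.79 log units; beyond the scatter) in this assay, so the group on the aromatic carbon, para to a large group, moves the number by itself, apart from the phenyl that carries it. The earlier steps shown here brought in the whole 4-bromophenyl and could not separate the two, whereas this change shows that bromo is not needed for a measurable value at this place. Nothing in the data at hand accounts for the size or direction of this step.

With only bromo and methoxy shown at this place, it remains open how an unsubstituted phenyl, a hydroxyl, an amine or a longer ethoxy would compare. Also open, going by these compounds, is whether methoxy would have the same effect elsewhere on the ring.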